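This account rests on a few compounds, and the source may have more. Where it says the series, first, only, none or still open, it means among the compounds named here.

Working notes on the series. Compound 1 `Cc1ccc(CS/C(=C/c2ccc(C)s2)C(=O)c2ccc(Cl)cc2)cc1` gives 50000 nM in a functional assay on DU-145 cells (Homo sapiens) for inhibition, read by trypan blue exclusion, with a stated time of 96 h (on this read-out lower numbers stand for stronger inhibition of growth and higher numbers for weaker inhibition of growth), and stands at the highest number of the three measured. Compound 3 `Cc1ccc(/C=C(/Sc2ccc(F)cc2)C(=O)c2ccc(Cl)cc2)s1` gives 25000 nM and sits nearest to it: the step of a 2.0-fold lower number from compound 1 to compound 3 (0.30 log units; within the scatter) involves 4-fluorophenyl in place of 4-methylbenzyl on a sulfur. Compound 2 `O=C(/C(=C\c1ccc(Br)cc1)Sc1ccc(Br)cc1)c1ccc(Cl)cc1` gives 1000 nM; it differs from compound 1 in two places at once, so its value cannot be assigned to either change alone, though it shows that much lower numbers are reachable within the shared core.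

Compound 4 `Cc1ccc(CS/C(=C/c2cc([N+](=O)[O-])ccc2F)C(=O)c2ccc(Cl)cc2)cc1` is not yet measured. It differs from compound 1 as follows: 2-fluoro-5-nitrophenyl in place of 5-methylthiophen-2-yl on a double-bonded chain carbon bound to a double-bonded chain carbon. Within the data shown here, no measured step touches the group on the double-bonded chain carbon; the only single-point step, from compound 1 to compound 3, concerns the sulfur substituent and lies within the scatter. Compound 2 carries a six-membered ring at the same place as compound 4, but with its second change left unresolved it gives only a loose pointer. A step toward lower numbers is therefore expected for compound 4, of size a 3.3-fold lower number from compound 1 to compound 4 (0.52 log units; beyond the scatter), with wide uncertainty. Compound 4 is estimated at 15000 nM, in the range 3000 nM to 50000 nM.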

Compound 4, concentration for 50% growth inhibition: 1000 nM
Compound 4: middle estimate off by 15-fold (1.18 log units), on the high side; the measured number lies below the stated range.
By their numbers in this assay, from the lowest: compounds 2 and 4 (each within the scatter of the next); then compounds 3 and 1 (each within the scatter of the next).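

In this assay, among these compounds, the group on a double-bonded chain carbon bound to a double-bonded chain carbon has a large bearing on the number: 2-fluoro-5-nitrophenyl in place of 5-methylthiophen-2-yl gives a 50-fold lower number from compound 1 to compound 4 (1.70 log units; beyond the scatter) and so stands beyond the scatter, while the one earlier single-place step, a 2.0-fold lower number from compound 1 to compound 3 (0.30 log units; within the scatter) on the sulfur, stayed within it. The low number is reached here with the 4-methylbenzyl group still on the sulfur. Nothing available explains the size of this step.

The swap changes the ring and adds the fluorine and the nitro group all at once, so the compounds shown cannot assign the step to any one of these. Going by these compounds, whether a plain phenyl ring, or an amine in place of the nitro group, would keep the low number remains open.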